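A few compounds are considered here, and "the series" means these few. Any claim that something is new, unique, unknown or untested is made for them only; others in the source may bear on it.

Measured so far:
compound 1 `N#CC1=C(N)N2C(=O)CSC2=C(C#N)C1c1ccc(Br)cc1` gives 43.6% in a functional assay on HCT-116 cells (Homo sapiens) for inhibition, read by MTT assay, with a stated time of 48 h, tested at 1 mg/mL; on this read-out higher numbers stand for more inhibition at the one concentration tested (going by the name of the read-out) and lower numbers for less inhibition
compound 2 `N#CC1=C(N)N2C(=O)CSC2=C(C#N)C1c1ccccc1Cl` gives 54.1%
compound 3 `N#CC1=C(N)N2C(=O)CSC2=C(C#N)C1c1ccc(Cl)cc1Cl` gives 29.9%

Of these three numbers compound 1 stands second highest: compound 2 sits above it by a number 10.5 percentage points higher from compound 1 to compound 2 (beyond the scatter), while compound 3 sits lowest, the gap between compound 1 and compound 3 being beyond the scatter.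

Compound 4 `COc1ccc(C2C(C#N)=C(N)N3C(=O)CSC3=C2C#N)cc1` differs from compound 1 by methoxy in place of bromo on an aromatic carbon. Neither measured step matches this change closely. The step of a number 10.5 percentage points higher from compound 1 to compound 2 (beyond the scatter) exchanged one halogen-bearing ring for another, and a number 24.2 percentage points lower from compound 2 to compound 3 (beyond the scatter) added a second chloro; both were modest. Among the measured compounds shown here, no measured step puts a methoxy in place of a halogen, so only a small shift is expected in this assay, with no clear direction. Compound 4 is therefore estimated at 40%, an expected step of a number 3.6 percentage points lower from compound 1 to compound 4 (within the scatter), within a range from 22% to 58%.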

Compound 4, a percentage reported as inhibition, at one concentration (the size of the read-out at that concentration, not a potency): 50.2%
Estimate against measurement, compound 4: 10.2 percentage points below, within the range that was stated.
By their numbers in this assay, from the lowest: compound 3; then compounds 1, 4 and 2 (each within the scatter of the next, the first and the last beyond it).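

Putting methoxy in place of bromo, para to a large group, gives a number 6.6 percentage points higher from compound 1 to compound 4 (within the scatter) in this assay. Among the compounds shown here, the earlier compounds carried only halogens on this ring, so this is the first sign that a group containing oxygen, with one hydrogen-bond acceptor, can sit here without a shift beyond the scatter. Nothing available explains why these two groups give such similar readings.

On these data alone, whether an amine or a carboxylic acid at this place would also stay within the scatter remains open. So does the outcome for a longer chain such as ethoxy.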